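Amide aryl swap on the azetidine ether series

The source may report more compounds than this note shows. Statements on the series, on what has been measured and on what is new or still open speak of the compounds shown alone.

Compound 1 `Cc1ccncc1C(=O)N1CC(Oc2cncc(N3C(=O)c4ccc(Cl)cc4C3(C)C)c2)C1` gives 4 nM in an assay on cells for inhibition of cytochrome P450 11B2, mitochondrial (Homo sapiens), read by HTRF (a lower number here means a stronger inhibitor, a higher number a weaker inhibitor), the higher of the two numbers reported, though the gap to its neighbour lies within the scatter. Compound 3 `CCS(=O)(=O)N1CCC(c2cncc(N3C(=O)c4ccc(Cl)cc4C3(C)C)c2)CC1` gives 3 nM in this assay, so the two are not told apart. Compound 2 `Cc1cc(Cl)ccc1C(=O)N(C)c1cccnc1` is reported in this assay as > 3000 nM, which is a limit and not a number, the limit being (the limit of > 3000 nM in this assay, at which 1 of the 3 values shown sits). Compound 4 `CC1(C)c2cc(Cl)ccc2C(=O)N1c1cncc(OC2CN(C(=O)c3ncccc3Cl)C2)c1` differs from compound 1 by 3-chloropyridin-2-yl in place of 4-methylpyridin-3-yl on a carbonyl carbon. Among the compounds with values here, no measured pair carries this change, so no step beyond the scatter is expected in either direction. Compound 4 is estimated at 5 nM, ranging from 1.5 nM to 15 nM, an expected step of a 1.3-fold higher number from compound 1 to compound 4 (0.10 log units; within the scatter).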

Compound 4, half-maximal inhibitory concentration in the cytochrome P450 11B2, mitochondrial assay: 5 nM
Beside the measured number, compound 4's estimate shows no gap at the digits printed; the range from low to high includes it.
By their numbers in the cytochrome P450 11B2, mitochondrial assay, from the lowest: compounds 3, 1 and 4 (each within the scatter of the next). At a limit, above all of these: compound 2.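

On the carbonyl carbon, 3-chloropyridin-2-yl in place of 4-methylpyridin-3-yl leaves the reading in the cytochrome P450 11B2, mitochondrial assay unchanged (a 1.3-fold higher number from compound 1 to compound 4 (0.10 log units; within the scatter)). This position therefore accepts both pyridinyl groups in that assay, yet in a physicochemical assay for solubility, in phosphate buffer, with a stated time of 2 h, at pH 6.5 (a higher number here means a more soluble compound, a lower number a less soluble compound), compound 1 gives 290 ug/mL and compound 4 gives 20 ug/mL, so the same change clearly separates the pair: the measured solubility of compound 1, 290 ug/mL, and of compound 4, 20 ug/mL, a 15-fold lower number (1.16 log units; beyond the scatter)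

The single pair changes chlorine, methyl and the ring's point of attachment together, and the compounds shown do not separate these. From the compounds shown here alone, how an amine in place of the chlorine would read in the cytochrome P450 11B2, mitochondrial assay and in the physicochemical assay stays open.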